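Isopropylcarbonyl Exchanged for 2-Methylbenzoyl on a Shared Core

This account rests on a few compounds, and the source may have more. Where it says the series, first, only, none or still open, it means among the compounds named here.

Among the compounds with values here, in an assay on THP-1 cells for displacement of a labelled ligand from C-C chemokine receptor type 1 (Homo sapiens) (on this read-out lower numbers stand for stronger inhibition and higher numbers for weaker inhibition), compound 1 `CC(C)C(=O)NC(C(=O)N1CCC(c2ccc(Cl)cc2)CC1)C(C)C` gives 388 nM, the highest of the three numbers measured so far. Compound 3 `CC[C@@H](NC(=O)c1ccccc1)C(=O)N1CCC(c2ccc(Cl)cc2)CC1` gives 121 nM, and compound 2 `Cc1ccccc1CCC(=O)N[C@@H](C(=O)N1CCC(c2ccc(Cl)cc2)CC1)C(C)C` gives 19 nM; both of these gaps to compound 1 lie beyond the scatter. Compound 4 `Cc1ccccc1C(=O)NC(C(=O)N1CCC(c2ccc(Cl)cc2)CC1)C(C)C` has not yet been measured. It differs from compound 1 in one place: 2-methylphenyl in place of isopropyl on a carbonyl carbon. The two measured compounds whose amide carbonyl carries a ring show lower numbers than compound 1, though neither differs from compound 1 in a single place, so this observation rests on three compounds only. In this assay compound 4 is expected to give 100 nM, with a range from 30 nM to 330 nM. The step of a 3.9-fold lower number from compound 1 to compound 4 (0.59 log units; beyond the scatter) is expected to be a decrease lying beyond the scatter.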

Compound 4, half-maximal inhibitory concentration: 36 nM
Compound 4: middle estimate off by 2.8-fold (0.44 log units), on the high side; low and high end bracket the measured number.
By their numbers in this assay, from the lowest: compounds 2 and 4 (each within the scatter of the next); then compound 3; then compound 1.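

In this assay the exchange of isopropyl for 2-methylphenyl on a carbonyl carbon brings an 11-fold lower number from compound 1 to compound 4 (1.03 log units; beyond the scatter) as a large step. Within the data shown here, this is the first comparison at this position with the rest of the molecule held constant, so the effect of the change can now be read directly from one matched pair. No available evidence bears on why the number falls. The compounds shown leave open what the methyl on the ring contributes. They also leave open how an amine or a longer chain in this place would compare with 2-methylphenyl.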